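A few compounds are considered here, and "the series" means these few. Any claim that something is new, unique, unknown or untested is made for them only; others in the source may bear on it.

In an assay on isolated protein for binding affinity to secreted frizzled-related protein 1 (Homo sapiens), read by fluorescence (a higher number here means a weaker inhibitor, a lower number a stronger inhibitor), compound 2 `CN(C)CC(=O)N1CCC[C@H]1C(=O)N1CCC(NS(=O)(=O)c2cc(S(=O)(=O)c3ccccc3)ccc2C(F)(F)F)CC1` gives 90 nM, the lowest of the two numbers recorded, with compound 1 within the scatter of it. Within the data shown here, compound 1 `CC(=O)N1CCC[C@H]1C(=O)N1CCC(NS(=O)(=O)c2cc(S(=O)(=O)c3ccccc3)ccc2C(F)(F)F)CC1` gives 160 nM, and a 1.8-fold lower number from compound 1 to compound 2 (0.25 log units; within the scatter) is the only measured step. Compound 3 `CN(C)c1ccc(C(=O)N2CCC[C@H]2C(=O)N2CCC(NS(=O)(=O)c3cc(S(=O)(=O)c4ccccc4)ccc3C(F)(F)F)CC2)cc1` differs from compound 2 by 4-(dimethylamino)phenyl in place of (dimethylamino)methyl on a carbonyl carbon. Among the measured compounds shown here, the single step seen concerns dimethylamino for hydrogen on the chain at that carbonyl carbon and was small, so it bears only loosely on an aromatic ring in place of the chain. No step beyond the scatter is therefore expected in this assay. Compound 3 is estimated at 100 nM, with a range from 30 nM to 350 nM. The step expected from this change is a 1.1-fold higher number from compound 2 to compound 3 (0.05 log units; within the scatter).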

Compound 3, half-maximal inhibitory concentration: 110 nM
Compound 3: middle estimate off by 1.1-fold (0.04 log units), on the low side; low and high end bracket the measured number.
By their numbers in this assay, from the lowest: compounds 2, 3 and 1 (each within the scatter of the next).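

Putting 4-(dimethylamino)phenyl in place of (dimethylamino)methyl on the carbonyl carbon gives, in this assay, a 1.2-fold higher number from compound 2 to compound 3 (0.09 log units; within the scatter), so a six-membered aromatic ring at this position leaves the number within the scatter. Against methyl at the same carbon, the same group gives a 1.5-fold lower number from compound 1 to compound 3 (0.16 log units; within the scatter), also with no step beyond the scatter. Nothing measured here explains these steps. Unsubstituted phenyl would show whether the dimethylamino group matters on the ring. From the compounds shown here alone, a carboxylic acid or a longer chain on this carbonyl carbon remains open.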